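The source may hold more compounds than are shown below. What is called first, only, known or untested is meant among the compounds shown, and "the series" means these compounds.

Compound 1 `COc1cc(OC)c(-c2coc3cc(OCc4ccccc4F)ccc3c2=O)cc1OC` gives 2100 nM
Compound 2 `COc1cc(OC)c(-c2coc3cc(OCc4ccc(Cl)cc4)ccc3c2=O)cc1OC` gives 1020 nM

In a functional assay on A-375 cells (Homo sapiens) for antiproliferative activity, read by MTT assay, with a stated time of 24 h (a lower number here means a stronger inhibitor, a higher number a weaker inhibitor), compound 2 holds the lower of the two numbers at 1020 nM and is the better of the pair. Compound 3 `COc1cc(OC)c(-c2coc3cc(OCc4cccc(Cl)c4)ccc3c2=O)cc1OC` is related to it by 3-chlorophenyl in place of 4-chlorophenyl on a saturated chain carbon bound to an oxygen on an aromatic ring and carries 3-chlorophenyl in place of 4-chlorophenyl on a saturated chain carbon bound to an oxygen on an aromatic ring. Among the measured compounds shown here, only one measured step bears on this place, the modest 2.1-fold lower number from compound 1 to compound 2 (0.31 log units; beyond the scatter), and it exchanges 2-fluorophenyl rather than moving the chlorine. A small change is therefore expected, with only a weak hint of direction, and the estimated step is a 1.3-fold higher number from compound 2 to compound 3 (0.11 log units; within the scatter). For compound 3 the expected value is 1300 nM, within an estimated range of 600 nM to 2700 nM.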

Compound 3, half-maximal inhibitory concentration: 980 nM
Compound 3: middle estimate off by 1.3-fold (0.12 log units), on the high side, and the stated range covers the measured number.
By their numbers in this assay, from the lowest: compounds 3 and 2 (each within the scatter of the next); then compound 1.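

In this assay the exchange of 4-chlorophenyl for 3-chlorophenyl gives a 1.0-fold lower number from compound 2 to compound 3 (0.02 log units; within the scatter) and so does not separate the two chlorophenyl groups at this place. The step from 2-fluorophenyl to 3-chlorophenyl, a 2.1-fold lower number from compound 1 to compound 3 (0.33 log units; beyond the scatter), shows that the earlier gain is not tied to 4-chlorophenyl alone. Nothing measured here explains these numbers. The compounds shown leave open whether 2-chlorophenyl would match the other two chlorophenyl groups, and whether an amine or a carboxylic acid on this phenyl ring would be tolerated. They also leave open the effect of a longer chain between the oxygen and the ring.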